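The compounds below may be only part of what the source reports. "The series", "measured", "known", "first", "only" and "open" are said of these compounds alone.

Measured so far in a functional assay on DLD-1 cells (Homo sapiens) for antiproliferative activity, read by CellTiter-Glo, with a stated time of 72 h; on this read-out lower numbers stand for stronger inhibition and higher numbers for weaker inhibition:
Compound 1, `COc1ccccc1-c1ccc(S(=O)(=O)N2CCC(N3CCC(C)CC3)CC2)cc1`: 26 nM
Compound 2, `Cc1cc(C)c(S(=O)(=O)N2CCN(C3CCN(C)CC3)CC2)c(C)c1`: 426 nM

Compound 1 stands lowest of the two numbers on this assay. Going by the values given here, compound 2 gives the higher number, and the gap between the two values lies beyond the usual scatter; no single-change step connects these two compounds, so only their two values can be compared.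

Compound 3, `COc1ccc(-c2ccc(S(=O)(=O)N3CCC(N4CCC(C)CC4)CC3)cc2)cc1`, has not yet been measured. It differs from compound 1 in one place: 4-methoxyphenyl in place of 2-methoxyphenyl on an aromatic carbon. The two compounds have the same atoms, joined differently.

Among the compounds with values here, no measured step of this kind is available, so the size of the change can only be estimated. In this assay the expected step, a 1.5-fold higher number from compound 1 to compound 3 (0.19 log units; within the scatter), is small, with no clear direction and most likely within the scatter. Compound 3 is therefore estimated at 40 nM, expected to fall between 10 nM and 160 nM.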

Compound 3, half-maximal inhibitory concentration: 263 nM
Compound 3: the middle estimate sits 6.6-fold (0.82 log units) below what was measured; the whole stated range lies below it.
By their numbers in this assay, from the lowest: compound 1; then compounds 3 and 2 (each within the scatter of the next).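

In this assay, 4-methoxyphenyl in place of 2-methoxyphenyl gives a 10-fold higher number from compound 1 to compound 3 (1.00 log units; beyond the scatter). Going by these compounds alone, this is the first single-change step here, and it lies beyond the scatter even though the compounds contain the same atoms. Where the methoxy group sits on this aromatic ring therefore makes a clear difference to the read-out, which the two unconnected earlier values could not show. No measurement available here accounts for this difference.

The compounds shown leave open how 3-methoxyphenyl or an unsubstituted phenyl would compare with the two methoxyphenyl groups. They also leave open whether a different group in the same place, such as 2-fluorophenyl or 2-hydroxyphenyl, would give a number nearer that of compound 1 or that of compound 3.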